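Halogen swap on the benzoxazolone core: bromo to fluoro

The compounds below may be only part of what the source reports. "The series", "measured", "known", "first", "only" and "open" are said of these compounds alone.

Compounds measured so far:
compound 1, `O=C(NCCCCc1ccccc1)n1c(=O)oc2cc(-c3ccc(F)cc3)ccc21`, 79 nM
compound 2, `O=C(NCCCCc1ccccc1)n1c(=O)oc2cc([N+](=O)[O-])ccc21`, 3 nM
compound 3, `O=C(NCCCCc1ccccc1)n1c(=O)oc2cc(Br)ccc21`, 31 nM

In an assay on HEK293 cells for inhibition of acid ceramidase (Homo sapiens), with a stated time of 10 min (a lower number here means a stronger inhibitor, a higher number a weaker inhibitor), compound 3 sits second highest of the three numbers. The number falls a 2.5-fold lower number from compound 1 to compound 3 (0.41 log units; beyond the scatter) and rises a 10-fold higher number from compound 2 to compound 3 (1.01 log units; beyond the scatter), both beyond the scatter, so compound 3 stands between the other two.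

Compound 4, `O=C(NCCCCc1ccccc1)n1c(=O)oc2cc(F)ccc21`, differs from compound 3 by fluoro in place of bromo on an aromatic carbon. Among the measured compounds shown here, no measured step exchanges one halogen for another on this core. The step of a 2.5-fold lower number from compound 1 to compound 3 (0.41 log units; beyond the scatter) shows that a bromo on the core is a modest gain over a 4-fluorophenyl, while a 10-fold higher number from compound 2 to compound 3 (1.01 log units; beyond the scatter) shows that a nitro is a large gain over a bromo. Neither tells how fluoro compares to bromo, so the expectation is for a small shift in this assay, if any, with the number for compound 4 somewhat closer to that of compound 1 than of compound 2.

Compound 4 is thus expected to give about 50 nM in this assay, within 15 nM to 160 nM, which means an expected step of a 1.6-fold higher number from compound 3 to compound 4 (0.21 log units; within the scatter).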

Compound 4, half-maximal inhibitory concentration: 31 nM
Estimate against measurement, compound 4: 1.6-fold (0.21 log units) above; low and high end bracket the measured number.
By their numbers in this assay, from the lowest: compound 2; then compounds 3 and 4 (each within the scatter of the next); then compound 1.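

In this assay, among the compounds shown here, the exchange of one halogen for the other on this aromatic carbon gives no change at the digits printed from compound 3 to compound 4 (within the scatter) and so does not separate fluoro from bromo, a comparison that no earlier step offered. Fluoro keeps the standing of bromo against the other two groups, with a 10-fold higher number from compound 2 to compound 4 (1.01 log units; beyond the scatter) on one side and a 2.5-fold lower number from compound 1 to compound 4 (0.41 log units; beyond the scatter) on the other, both beyond the scatter. Among the four compounds, the two halogens therefore fall together, with nitro on the low side and 4-fluorophenyl on the high side.

Nothing available on these compounds accounts for the matching numbers or for the distance of nitro from the halogens. Still open, going by these compounds, is where a nitrile, an amine or a carboxylic acid on this aromatic carbon would fall relative to nitro and the two halogens.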